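Replacing a Cyclohexylmethyl Anchor: Oxane to Direct Cyclohexyl

This account rests on a few compounds, and the source may have more. Where it says the series, first, only, none or still open, it means among the compounds named here.

Measured compounds:
compound 1, `c1ccc2c(c1)CN[C@@H](CN(CCCCN(Cc1ccncc1)Cc1ccncc1)[C@H]1CCCc3cccnc31)C2` — 832 nM
compound 2, `c1ccc2c(c1)CN[C@@H](CN(CCCCNCC1CCCCC1)[C@H]1CCCc3cccnc31)C2` — 158 nM
compound 3, `c1ccc2c(c1)CN[C@@H](CN(CCCCNCC1CCOCC1)[C@H]1CCCc3cccnc31)C2` — 52.9 nM

These three share one core and differ only in the group carried on the outer amine nitrogen. In a functional assay on cells for antagonist activity at C-X-C chemokine receptor type 4 (Homo sapiens), read by fluorescence and calcium flux, with stated times of 25 min and 90 s (a higher number here means a weaker inhibitor, a lower number a stronger inhibitor), compound 3 gives the lowest of the three numbers; its nearest neighbour is compound 2, and compound 1 lies furthest from it. Among the compounds with values here, the one single-point step among them, a 3.0-fold lower number from compound 2 to compound 3 (0.48 log units; beyond the scatter), is the swap of cyclohexyl for oxan-4-yl on a saturated chain carbon bound to an amine nitrogen.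

Compound 4, `c1ccc2c(c1)CN[C@@H](CN(CCCCNC1CCCCC1)[C@H]1CCCc3cccnc31)C2`, is not yet measured. It differs from compound 3 by cyclohexyl in place of (oxan-4-yl)methyl on an amine nitrogen; cut one bond further out, the change reads ((oxan-4-yl)methyl)amino to cyclohexylamino. Two things move at once: the ring oxygen is lost, and the ring now sits directly on the amine nitrogen rather than on a chain carbon. Within the data shown here, only the step from compound 2 to compound 3 bears on this, and it does so only in part, since it covers the oxygen but not the shortening. Because a 3.0-fold lower number from compound 2 to compound 3 (0.48 log units; beyond the scatter) ran toward a stronger inhibitor on adding the oxygen, the reverse is expected here, with the direct attachment an unmeasured factor. Compound 4 is therefore expected at 180 nM, between 60 nM and 550 nM, a step of a 3.4-fold higher number from compound 3 to compound 4 (0.53 log units; beyond the scatter) that is estimated, not measured.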

Compound 4, half-maximal inhibitory concentration: 75.2 nM
Beside the measured number, compound 4's estimate is 2.4-fold (0.38 log units) above it, within the range that was stated.
By their numbers in this assay, from the lowest: compounds 3 and 4 (each within the scatter of the next); then compound 2; then compound 1.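

The all-carbon ring does not depend on the oxygen to reach this level: in this assay, a 1.4-fold higher number from compound 3 to compound 4 (0.15 log units; within the scatter) leaves cyclohexyl on the amine nitrogen indistinguishable from (oxan-4-yl)methyl at this position, even though the earlier step had favoured the oxygen-bearing ring over its carbon counterpart on the same chain carbon. Within the data shown here, the other new step isolates what the earlier compounds could not, the direct attachment of the ring to the amine nitrogen: a 2.1-fold lower number from compound 2 to compound 4 (0.32 log units; beyond the scatter) is a modest change beyond the scatter and is similar in size to the step gained by oxan-4-yl in place of cyclohexyl, so removing the chain carbon and adding the ring oxygen each separately lead from compound 2 to the same level. No measurement offered here accounts for either step.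

On these data alone, what remains open is whether oxan-4-yl set directly on the amine nitrogen would combine these two changes or add nothing further. Nor do these compounds show how a longer chain, such as 2-cyclohexylethyl, would read on the same amine nitrogen.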